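The source may hold more compounds than are shown below. What is called first, only, known or untested is meant among the compounds shown, and "the series" means these compounds.

In an ADME assay on HFF cells (Homo sapiens) for cytotoxicity, with a stated time of 8 days (on this read-out lower numbers stand for higher toxicity in this test and higher numbers for lower toxicity in this test), compound 1 (`COCCOc1nc(N)nc2c1ncn2/C=C1/CC1(CO)CO`) gives > 300000 nM as a limit. Compound 2 (`CCCCCCCCSc1nc(N)nc2c1ncn2/C=C1/CC1(CO)CO`), which carries octylsulfanyl, gives > 300000 nM as a limit too. Compound 3 (`Nc1nc(NC2CCCCC2)c2ncn(/C=C3/CC3(CO)CO)c2n1`), which carries cyclohexylamino, stands at > 300000 nM and this is again a limit, not a number. The series thus shows only the limit of > 300000 nM in this assay, at which 3 of the 3 values shown sit, and nothing finer.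

Compound 4 (`CSc1nc(N)nc2c1ncn2/C=C1/CC1(CO)CO`) has methylsulfanyl in place of cyclohexylamino on an aromatic carbon. For the measured compounds named here, three measured steps bear on this change, namely a step that the two limits leave unreadable from compound 1 to compound 2 and a step that the two limits leave unreadable from compound 1 to compound 3 and a step that the two limits leave unreadable from compound 2 to compound 3 and none of them gives a size. On that evidence, no step beyond the scatter is expected in this assay in either direction, and compound 4 is expected to report the same limit. The estimated move is a number no higher from compound 3 to compound 4 (the limit leaves the size open) and it is expected to lie within the scatter. For compound 4 the estimated value is 300000 nM with an expected range from 120000 nM to 300000 nM in this test.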

Compound 4, half-maximal cytotoxic concentration: > 300000 nM
Compound 4: no number, only a limit; the forecaster's own chance of this, stated with the estimate: 85%; the middle value sits exactly at the limit.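

In this assay, compound 4 gives only a limit, as do compound 1, compound 2 and compound 3, so no step among these compounds can be read: the limit of > 300000 nM in this assay, at which 4 of the 4 values shown sit.

The compounds shown leave open whether any of these groups changes the half-maximal cytotoxic concentration at all, and by how much.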